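The compounds below may be only part of what the source reports. "The series", "measured", "known", "first", "only" and "open" are said of these compounds alone.

In an assay on isolated protein for inhibition of protein deacetylase HDAC6 (Homo sapiens), with a stated time of 60 min (on this read-out lower numbers stand for stronger inhibition and higher numbers for weaker inhibition), compound 1 `CS(=O)(=O)c1ccc(-n2ccc3cnc(Nc4cnn(CCCCCCC(=O)NO)c4)nc32)cc1` gives 5.9 nM, and compound 2 `COc1cccc(Cn2ccc3cnc(Nc4cnn(CCCCCCC(=O)NO)c4)nc32)c1` gives 28.8 nM. Compound 2 thus holds the higher of the two numbers in this assay, its nearest neighbour being compound 1, separated by a 4.9-fold higher number from compound 1 to compound 2 (0.69 log units; beyond the scatter). Compound 3 `O=C(CCCCCCn1cc(Nc2ncc3ccn(CC4CCCCC4)c3n2)cn1)NO` differs from compound 2 by cyclohexyl in place of 3-methoxyphenyl on a saturated chain carbon bound to an aromatic nitrogen. For the measured compounds named here, the single step on hand concerns the group on the aromatic nitrogen itself, not a saturated ring replacing an aromatic one, so its bearing is indirect. For compound 3 the expected step in this assay is a 1.4-fold higher number from compound 2 to compound 3 (0.14 log units; within the scatter), a small rise that may fall within the scatter. The estimate for compound 3 in this assay is 40 nM, in the range 12 nM to 130 nM.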

Compound 3, half-maximal inhibitory concentration: 88 nM
For compound 3 the middle estimate is 2.2-fold (0.34 log units) below the measured one; the range from low to high includes it.
By their numbers in this assay, from the lowest: compound 1; then compound 2; then compound 3.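

Cyclohexyl in place of 3-methoxyphenyl on a saturated chain carbon bound to an aromatic nitrogen gives a 3.1-fold higher number from compound 2 to compound 3 (0.49 log units; beyond the scatter) in this assay and removes both the aromatic ring and the methoxy oxygen. Cyclohexylmethyl in place of 4-(methylsulfonyl)phenyl on an aromatic nitrogen gives a 15-fold higher number from compound 1 to compound 3 (1.17 log units; beyond the scatter) and the widest gap among these compounds. Nothing measured here explains either step.

Whether the ring or the methoxy oxygen accounts for the rise stays open, since both change together. A plain benzyl or a morpholinoethyl group on the same nitrogen would help to separate them.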